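Aminomethyl for pyrrolyl on the sulfone amide series

A few compounds are considered here, and "the series" means these few. Any claim that something is new, unique, unknown or untested is made for them only; others in the source may bear on it.

Of the compounds shown here, three sharing a tetralin-like sulfone core have been measured in an assay on isolated protein for displacement of a labelled ligand from 5-hydroxytryptamine receptor 6 (Homo sapiens); on this read-out higher numbers stand for weaker inhibition and lower numbers for stronger inhibition. Compound 1 `CN(C)CC1CCCc2cc(S(=O)(=O)c3ccccc3)ccc21` gives 0.0631 nM, and compound 2 `O=C1CN=C(NC[C@@H]2CCCc3cc(S(=O)(=O)c4cccc(F)c4)ccc32)N1` gives 0.1 nM. Compound 3 `O=C(NC[C@@H]1CCCc2cc(S(=O)(=O)c3cccc(F)c3)ccc21)c1ccc[nH]1` gives 5.01 nM, the highest of the three numbers; its nearest neighbour is compound 2 and its furthest is compound 1. Among the measured compounds shown here, the only single-point step on record, a 50-fold higher number from compound 2 to compound 3 (1.70 log units; beyond the scatter), shows that the group on the amine nitrogen of this core moves the number a long way.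

Compound 4 `NCC(=O)NC[C@@H]1CCCc2cc(S(=O)(=O)c3cccc(F)c3)ccc21` differs from compound 3 by aminomethyl in place of 1H-pyrrol-2-yl on a carbonyl carbon. For the measured compounds named here, no measured step covers this exact exchange, since the one recorded step swapped a five-membered non-aromatic ring for the pyrrolyl ring rather than for an open chain. The data therefore offer only the sensitivity of this position and the low numbers of compound 1 and compound 2 as guidance. Given that compound 3 sits far above both, a move back toward lower numbers seems more likely than a further rise, though the size is uncertain. Compound 4 is therefore expected to give 0.8 nM, within 0.15 nM to 4 nM, a step of a 6.3-fold lower number from compound 3 to compound 4 (0.80 log units; beyond the scatter) being expected.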

Compound 4, inhibition constant: 0.316 nM
Beside the measured number, compound 4's estimate is 2.5-fold (0.40 log units) above it, within the range that was stated.
By their numbers in this assay, from the lowest: compounds 1 and 2 (each within the scatter of the next); then compound 4; then compound 3.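

In this assay, exchanging 1H-pyrrol-2-yl for aminomethyl on the carbonyl carbon brings the number down a long way (a 16-fold lower number from compound 3 to compound 4 (1.20 log units; beyond the scatter)), a large step that shows the earlier rise on this amine nitrogen is not tied to the carbonyl itself, which compounds 3 and 4 share, but depends on what the carbonyl carries. The open chain of compound 4 also shows that a low number here does not need the five-membered non-aromatic ring of compound 2, although the ring and the chain do not give the same result (a 3.2-fold higher number from compound 2 to compound 4 (0.50 log units; beyond the scatter)), a modest step that is still beyond the scatter. Nothing at hand bears on why either step has the size it has.

What the compounds shown leave open is whether the terminal amine of the aminomethyl group accounts for the step, a question that a hydroxymethyl or a methyl group on the same carbonyl carbon would address. They also leave open how the number responds to a longer chain such as aminoethyl, to a dimethylamino end on the chain, or to a carboxylic acid at that end.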